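This account rests on a few compounds, and the source may have more. Where it says the series, first, only, none or still open, it means among the compounds named here.

Of the compounds shown here, three built on one shared core have been tested in a functional assay on MDA-MB-231 cells (Homo sapiens) for inhibition, read by sulforhodamine B assay, tested at 10 uM; on this read-out lower numbers stand for less inhibition and higher numbers for more inhibition at the one concentration tested (going by the name of the read-out). Compound 1 `CC(=O)N1N=C(c2ccc(N3CCN(C)CC3)cc2)CC1c1ccc(N(C)C)cc1` gives -1%. Compound 2 `CN1CCN(c2ccc(C3=NN(C(=O)c4ccc(C(F)(F)F)cc4)C(c4ccc(N(C)C)cc4)C3)cc2)CC1` gives 55.4%. Compound 3 `CN1CCN(c2ccc(C3=NN(S(=O)(=O)C4CC4)C(c4ccc(N(C)C)cc4)C3)cc2)CC1` gives 3.7%, which places it second highest of the three, close to compound 1 and far from compound 2. The measured steps are a number 4.7 percentage points higher from compound 1 to compound 3 (within the scatter), a number 56.4 percentage points higher from compound 1 to compound 2 (beyond the scatter) and a number 51.7 percentage points lower from compound 2 to compound 3 (beyond the scatter). Compound 4 `CN1CCN(c2ccc(C3=NN(S(=O)(=O)c4ccc(F)cc4)C(c4ccc(N(C)C)cc4)C3)cc2)CC1` differs from compound 3 in one place: 4-fluorophenyl in place of cyclopropyl on a sulfonyl sulfur. Among the measured compounds shown here, no measured step swaps a cyclopropyl for an aromatic ring on a sulfonyl sulfur, so the bearing is indirect; the only large step, a number 56.4 percentage points higher from compound 1 to compound 2 (beyond the scatter), accompanied an aromatic ring entering on a carbonyl carbon. A modest rise is therefore expected, with an estimated step of a number 21.3 percentage points higher from compound 3 to compound 4 (beyond the scatter). Compound 4 is estimated at 25%, between -5% and 55%.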

Compound 4, a percentage reported as inhibition, at one concentration (the size of the read-out at that concentration, not a potency): 15.7%
Compound 4: middle estimate off by 9.3 percentage points, on the high side; measured number inside the range.
By their numbers in this assay, from the lowest: compounds 1 and 3 (each within the scatter of the next); then compound 4; then compound 2.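

In this assay the change from cyclopropyl to 4-fluorophenyl on a sulfonyl sulfur gives a number 12 percentage points higher from compound 3 to compound 4 (beyond the scatter) and so shows that the number at this position responds to the group carried on the sulfur. The same (4-fluorophenyl)sulfonyl gives a number 16.7 percentage points higher from compound 1 to compound 4 (beyond the scatter) where it replaces acetyl but a number 39.7 percentage points lower from compound 2 to compound 4 (beyond the scatter) where it replaces (4-(trifluoromethyl)phenyl)carbonyl, so it falls well short of that aromatic carbonyl group. Nothing measured here explains the sizes of these steps.

Still open, going by these compounds, is what an unsubstituted phenyl, a phenyl ring carrying an amine, or a longer carbon chain on the sulfonyl sulfur would give.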